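From 4-chlorophenyl to 3,4-dichlorophenyl in the series

A few compounds are considered here, and "the series" means these few. Any claim that something is new, unique, unknown or untested is made for them only; others in the source may bear on it.

In a functional assay on K562 cells (Homo sapiens) for inhibition, read by MTT assay, with a stated time of 24 h (on this read-out lower numbers stand for stronger inhibition and higher numbers for weaker inhibition), compound 1 `O=C(Cn1c(=O)c(/C=C\c2ccncc2)nc2ccccc21)Nc1ccccc1` gives 55500 nM. Compound 2 `O=C(Cn1c(=O)c(/C=C\c2ccncc2)nc2ccccc21)Nc1ccc(F)cc1` gives > 100000 nM, which is a limit. Compound 3 `O=C(Cn1c(=O)c(/C=C\c2ccncc2)nc2ccccc21)Nc1ccc(Cl)cc1` gives > 50400 nM, which is also a limit, so it has no exact place on the scale.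

Compound 4 `O=C(Cn1c(=O)c(/C=C\c2ccncc2)nc2ccccc21)Nc1ccc(Cl)c(Cl)c1` differs from compound 3 by chloro in place of hydrogen on an aromatic carbon. This is chloro in place of hydrogen on an aromatic carbon, ortho to a chloro group, taking 4-chlorophenyl to 3,4-dichlorophenyl.

Among the measured compounds shown here, two measured steps bear on this change. Fluoro in place of hydrogen gave an at least 1.8-fold higher number from compound 1 to compound 2 (0.25 log units; that floor lies within the scatter). Chloro in place of hydrogen, the closer match, gave a step that the limit leaves unreadable from compound 1 to compound 3. Neither step gives a size beyond the scatter, so no clear move in either direction is expected. For the measured compounds named here, the only exact anchor is compound 1 at 55500 nM.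

The expected change is a step that the limit leaves unreadable from compound 3 to compound 4. Compound 4 is estimated at 60000 nM, with an expected range of 25000 nM to 130000 nM.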

Compound 4, half-maximal inhibitory concentration: > 100000 nM
Compound 4: only a limit was reported; the forecaster's own chance of this, stated with the estimate: 50%; middle value at least 1.6-fold (0.22 log units) from the limit.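

In this assay compound 4 gives > 100000 nM, which is a limit, so a second chloro, ortho to a chloro group, gives no exact place on the scale either. Among the compounds shown here, the only readable step is an at least 1.8-fold higher number from compound 1 to compound 4 (0.25 log units; that floor lies within the scatter), so 3,4-dichlorophenyl is not separated from phenyl beyond the scatter. The steps from compound 2 and compound 3 to compound 4 cannot be read, and compound 4 joins compound 2 at the same ceiling: the limit of > 100000 nM in this assay, at which 2 of the 4 values shown sit.

For the compounds shown here, compound 1, at 55500 nM, remains the only exact value, so the size of any effect of halogens on this ring stays open. Also open, as far as these compounds go, is whether an amine or a carboxylic acid on the phenyl ring would give an exact value in this assay.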